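The source may hold more compounds than are shown below. What is called first, only, known or untested is meant among the compounds shown, and "the series" means these compounds.

compound 1 `Cc1cc(C(=O)NCc2ccncc2)nn1Cc1cc(Cl)ccc1OCc1ccccc1`: > 3.7
compound 2 `CC(=O)Nc1cc(C)n(Cc2cc(Cl)ccc2OCc2ccccc2)n1`: > 3.7

In a physicochemical assay for lipophilicity, at pH 7.4 (a higher number here means a more lipophilic compound, a lower number a more polar compound), compound 2 gives > 3.7, which is a limit of the assay and not a number. Compound 2 thus shares (the limit of > 3.7 in this assay, at which 2 of the 2 values shown sit). Within the data shown here, the only measured step, a step that the two limits leave unreadable from compound 1 to compound 2, gives no size to build on.

Compound 3 `Cc1cc(NC(=O)C2CCOCC2)nn1Cc1cc(Cl)ccc1OCc1ccccc1` carries oxan-4-yl in place of methyl on a carbonyl carbon. With no readable size to draw on, the expected change is small, with no firm direction and nothing beyond the scatter: a step that the limit leaves unreadable from compound 2 to compound 3 is expected. For compound 3 the estimate is 4, with an expected range from 3.5 to 4.6.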

Compound 3, distribution coefficient: > 3.7
Compound 3 was reported as a limit (the forecaster's own chance of this, stated with the estimate: 70%); the middle value is on the limit's open side.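

Compound 1, compound 2 and compound 3 all stand at a limit of the assay and not at a number, so no step among them can be read: the limit of > 3.7 in this assay, at which 3 of the 3 values shown sit.

The compounds shown leave open how far apart these three lie in this assay, and whether any step among them is large or small.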